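The source may hold more compounds than are shown below. What is called first, only, known or untested is meant among the compounds shown, and "the series" means these compounds.

Measured compounds in the series:

Compound 1 `Cc1ccccc1-n1nncc1CN1C(=O)C2(C(C#N)=C(N)Oc3c2c2nc4ccccc4nc2c2ccccc32)c2ccccc21` — in an ADME assay on L02 cells (Homo sapiens) for antiproliferative activity, read by MTT assay, with a stated time of 48 h (on this read-out lower numbers stand for stronger inhibition and higher numbers for weaker inhibition), compound 1 gives > 50000 nM, a limit of the assay rather than a number.
Compound 2 `N#CC1=C(N)Oc2c(c3nc4ccccc4nc3c3ccccc23)C12C(=O)N(Cc1cnnn1-c1ccc(F)cc1)c1ccccc12` — in this assay compound 2 gives > 50000 nM, again only a limit.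
Compound 3 `CCOc1ccccc1-n1nncc1CN1C(=O)C2(C(C#N)=C(N)Oc3c2c2nc4ccccc4nc2c2ccccc32)c2ccccc21` — in this assay compound 3 gives > 50000 nM, also a limit.

Where compound 2 stands: its value is a limit, and it sits with the other two at the limit of > 50000 nM in this assay, at which 3 of the 3 values shown sit, so no number places it relative to compound 1 or compound 3 within the series.

The next compound to be read is compound 4 `Cc1ccc(-n2nncc2CN2C(=O)C3(C(C#N)=C(N)Oc4c3c3nc5ccccc5nc3c3ccccc43)c3ccccc32)c(C)c1`. Its difference from compound 2 is 2,4-dimethylphenyl in place of 4-fluorophenyl on an aromatic nitrogen; the change concerns the group carried on the aromatic nitrogen of the five-membered ring with three nitrogens, and nothing else in the shared core.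

The measured steps that bear on it are the replacements of that same group: a step that the two limits leave unreadable from compound 1 to compound 2 and a step that the two limits leave unreadable from compound 2 to compound 3, with a step that the two limits leave unreadable from compound 1 to compound 3 as a third case. None of them gives a readable size, as all three values rest at the limit of > 50000 nM in this assay, at which 3 of the 3 values shown sit. Three changes of this group, spanning methyl, fluorine and ethoxy substitution, produced no measurable number, so the expectation for compound 4 in this assay is a step that the limit leaves unreadable from compound 2 to compound 4, most probably again reported as a limit. The estimate for compound 4 is 60000 nM with a range from 20000 nM to 200000 nM.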

Compound 4, half-maximal inhibitory concentration: > 50000 nM
Compound 4: a limit, no number (the forecaster's own chance of this, stated with the estimate: 85%); the middle value does not contradict the limit.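

In this assay compound 4 gives > 50000 nM as a limit and not a number. No step to compound 4 from compound 1, compound 2 or compound 3 can be read: the limit of > 50000 nM in this assay, at which 4 of the 4 values shown sit.

The compounds shown leave open whether any group on the aromatic nitrogen gives a measurable value on this read-out, and how far these four compounds differ.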